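Swapping an aryl substituent on a boron-containing cytotoxicity probe

A few compounds are considered here, and "the series" means these few. Any claim that something is new, unique, unknown or untested is made for them only; others in the source may bear on it.

Of the compounds shown here, two sharing one core have been tested in an ADME assay on WI-38 cells (Homo sapiens) for cytotoxicity, read by MTT assay, with a stated time of 72 h; a higher number here means a weaker inhibitor, a lower number a stronger inhibitor. Compound 1 `Cc1cc(C)c(NC(=O)CCc2cccc3c2B(O)OC3)c(C)c1` gives 74000 nM. Compound 2 `O=C(CCc1cccc2c1B(O)OC2)Nc1cccc(-c2ccc(Cl)cc2)c1` gives 9800 nM, the lower of the two numbers, and the gap to compound 1 lies beyond the usual scatter. Compound 3 `CC(=O)c1cccc(-c2cccc(NC(=O)CCc3cccc4c3B(O)OC4)c2)c1` has not been measured yet; it differs from compound 2 by 3-acetylphenyl in place of 4-chlorophenyl on an aromatic carbon. For the measured compounds named here, no measured pair shows this kind of change, so the step is expected to be small, either none beyond the scatter or a modest rise, giving a 1.5-fold higher number from compound 2 to compound 3 (0.18 log units; within the scatter). In this assay compound 3 is therefore expected near 15000 nM, between 6000 nM and 40000 nM.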

Compound 3, half-maximal inhibitory concentration: 2200 nM
The estimate for compound 3 lay 6.8-fold (0.83 log units) above the measured number; the whole stated range lies above it.
By their numbers in this assay, from the lowest: compound 3; then compound 2; then compound 1.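

For the compounds shown here, the aryl group on this aromatic carbon clearly affects the result: in this assay, 3-acetylphenyl in place of 4-chlorophenyl gives a 4.5-fold lower number from compound 2 to compound 3 (0.65 log units; beyond the scatter) and this is the first step measured at this place. Compound 3 therefore has the lowest number of the three compounds. Nothing measured here explains the step.

The change alters both the substituent and its place on the ring, and these two effects remain tangled. Also open, from the compounds shown here alone, is how a phenyl ring carrying an amine or a carboxylic acid would read at this position.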